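A few compounds are considered here, and "the series" means these few. Any claim that something is new, unique, unknown or untested is made for them only; others in the source may bear on it.

Of the compounds shown here, two have so far been measured in a functional assay on MCF7 cells (Homo sapiens) for inhibition, read by MTT assay, with a stated time of 48 h; a higher number here means a weaker inhibitor, a lower number a stronger inhibitor. Compound 1 `COc1ccc(/C=C/c2cc(OC)cc(OC)c2/C=C/C(=O)N2CCN(C)CC2)cc1` gives 2290 nM, and compound 2 `CCCCNC(=O)/C=C/c1c(/C=C/c2ccc(OC)cc2)cc(OC)cc1OC` gives 1330 nM. The two share the same core and differ only in the group on the carbonyl carbon, butylamino in place of 4-methylpiperazin-1-yl, and that change brought a 1.7-fold lower number from compound 1 to compound 2 (0.24 log units; within the scatter). Of these two numbers compound 2 holds the lower one, but since the gap to compound 1 lies within the scatter, the two cannot really be told apart.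

Compound 3 `COc1ccc(/C=C/c2cc(OC)cc(OC)c2/C=C/C(=O)NC(C)C)cc1` has not yet been measured. It differs from compound 2 in one place: isopropyl in place of butyl on an amide-type nitrogen. Among the compounds with values here, the only measured step that bears on this change is the one at the same amide-type nitrogen, which swapped out the whole group on the carbonyl carbon and still stayed within the scatter. A smaller trim, butyl to isopropyl, is therefore expected to leave the number close to that of compound 2, with no step beyond the scatter in either direction. For compound 3 the estimate is 1500 nM, within 600 nM to 4000 nM. This amounts to an expected step of a 1.1-fold higher number from compound 2 to compound 3 (0.05 log units; within the scatter).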

Compound 3, half-maximal inhibitory concentration: 2560 nM
Estimate against measurement, compound 3: 1.7-fold (0.23 log units) below; the measured number falls inside the stated range.
By their numbers in this assay, from the lowest: compounds 2, 1 and 3 (each within the scatter of the next).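

Trimming the chain on the amide-type nitrogen from butyl to isopropyl gives, in this assay, a 1.9-fold higher number from compound 2 to compound 3 (0.28 log units; within the scatter), so this first change to the chain alone, with the amide kept in place, cannot be told from repeat-measurement noise. Replacing the whole 4-methylpiperazin-1-yl group on the carbonyl carbon with isopropylamino gives a 1.1-fold higher number from compound 1 to compound 3 (0.05 log units; within the scatter), and together with the earlier step this means that none of the three groups on the carbonyl carbon can be separated from the others, even though one carries a ring and the other two carry open chains. Nothing shown offers any explanation for these numbers.

Within the data shown here, every step so far stays within the scatter, so it remains unknown which kind of change at this position, if any, would clearly move the number in this assay. A much longer chain such as octyl, a benzyl group on the nitrogen, or a chain ending in a carboxylic acid or a free amine would test whether this flat picture extends beyond butyl, isopropyl and 4-methylpiperazin-1-yl.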